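From Compound 3 to Compound 4: Expecting Another Limit

The source may hold more compounds than are shown below. What is called first, only, known or untested is meant among the compounds shown, and "the series" means these compounds.

Compound 3 `CCCc1nnc(SCc2ccccc2)n1N1C(=O)c2ccccc2C1=O` stands at the ceiling of the numbers shown. In a functional assay on MKN-45 cells (Homo sapiens) for cytotoxicity, read by MTT assay, with a stated time of 48 h (a lower number here means a stronger inhibitor, a higher number a weaker inhibitor), compound 3 gives only a limit of > 200000 nM. Compound 1 `Cc1nnc(SCc2ccccc2)n1N1C(=O)c2ccccc2C1=O` likewise reaches only the limit > 200000 nM. Compound 2 `CCc1nnc(SCC(=O)c2ccc(C)cc2)n1N1C(=O)c2ccccc2C1=O` also sits at the limit > 200000 nM. The step that the two limits leave unreadable from compound 1 to compound 3 is thus unreadable, and the limit of > 200000 nM in this assay, at which 3 of the 3 values shown sit, is all the evidence there is. Compound 4 `CCCc1nnc(SCC(=O)c2ccc(C)cc2)n1N1C(=O)c2ccccc2C1=O` differs from compound 3 by (4-methylphenyl)carbonyl in place of phenyl on a saturated chain carbon bound to a sulfur. Within the data shown here, no measured step gives a direction for this change. Compound 4 is expected at the limit too because compound 2, which carries the same group, gives > 200000 nM. The step that the limit leaves unreadable from compound 3 to compound 4 is therefore expected to be unreadable. For compound 4 the estimate is 250000 nM, with a range from 100000 nM to 600000 nM.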

Compound 4, half-maximal inhibitory concentration: > 200000 nM
Compound 4 ended at the assay's limit (the forecaster's own chance of this, stated with the estimate: 85%); the middle value lies beyond the limit too.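

Compound 4 adds no readable step: its comparisons with compound 2 and compound 3 both join limits, not numbers: the limit of > 200000 nM in this assay, at which 4 of the 4 values shown sit.

The compounds shown leave open whether any of these changes alters potency in this assay.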